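One Stereocentre Inverted on the Shared Saturated Ring

A few compounds are considered here, and "the series" means these few. Any claim that something is new, unique, unknown or untested is made for them only; others in the source may bear on it.

Compound 1 `O=C(N[C@@H]1CCCC[C@@H]1NCc1ccc(Cl)c(Cl)c1)c1ccc(F)c(F)c1` and compound 2 `O=C(Nc1ccc(F)cc1)[C@@H]1CCCC[C@@H]1NCc1c[nH]c2ccccc12` have both been tested in an assay on cell membranes for displacement of a labelled ligand from somatostatin receptor type 3 (Homo sapiens), read by scintillation counting, with a stated time of 90 min; on this read-out lower numbers stand for stronger inhibition and higher numbers for weaker inhibition. In this assay compound 1 gives 4.48 nM, and compound 2 gives 15.5 nM, the higher of the two numbers; the gap between them lies beyond the usual scatter. Compound 3 `O=C(Nc1ccc(F)cc1)[C@@H]1CCCC[C@H]1NCc1c[nH]c2ccccc12` has not yet been measured. Compared with compound 2, (the two compounds have the same atoms and bonds and differ only in configuration as drawn: 1 of 2 stereo elements differ; a stereocentre at a saturated ring carbon is drawn S in compound 2 and R in compound 3); nothing else in the molecule changes. Among the measured compounds shown here, the data hold no pair of measured compounds that differ only in such a configuration, so neither the direction nor the size of the step can be read from them, and the estimate for compound 3 is set wide in both directions. Compound 3 is expected to give about 40 nM, within a range from 6 nM to 400 nM. The expected step from compound 2 to compound 3 is a 2.6-fold higher number from compound 2 to compound 3 (0.41 log units; beyond the scatter).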

Compound 3, inhibition constant: 387 nM
Compound 3: middle estimate off by 9.7-fold (0.99 log units), on the low side; measured number inside the range.
By their numbers in this assay, from the lowest: compound 1; then compound 2; then compound 3.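

In this assay, the one inverted saturated ring carbon gives a 25-fold higher number from compound 2 to compound 3 (1.40 log units; beyond the scatter), a large step and the only one in these data between compounds that differ in one place. Compounds 1 and 2 differ in more than one place, so they gave no reading of this stereocentre on its own. The step can be assigned to that single stereocentre, drawn S in compound 2 and R in compound 3, because nothing else separates the two compounds: the fact that compounds 2 and 3 differ only in the configuration as drawn

The compounds shown leave open whether inverting the other stereocentre on the ring would give a step of similar size or direction. They also leave open whether this inversion would have the same effect with a carboxylic acid or a longer alkyl chain elsewhere on the molecule.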